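This account rests on a few compounds, and the source may have more. Where it says the series, first, only, none or still open, it means among the compounds named here.

Measured in a functional assay on HT-29 cells (Homo sapiens) for antiproliferative activity, read by MTT assay, with a stated time of 96 h; a higher number here means a weaker inhibitor, a lower number a stronger inhibitor:

- compound 1 `CCN(CC)c1ccc(N2C(=O)NC3(CSC4=C3C(=O)c3ncccc3C4=O)C2=O)cc1`: 50 nM
- compound 2 `O=C1NNC(=O)C2(CSC3=C2C(=O)c2ncccc2C3=O)N1`: 1580 nM; 1600 nM; 1600 nM (3 entries)
- compound 3 `CCCc1ccc(N2C(=O)NC3(CSC4=C3C(=O)c3ncccc3C4=O)C2=O)cc1`: 1 nM

Of the two compounds with a single number, compound 1 50 nM stands higher, and compound 3 is its nearest neighbour. Compound 4 `CCc1ccc(N2C(=O)NC3(CSC4=C3C(=O)c3ncccc3C4=O)C2=O)cc1` has not yet been measured. It arises from compound 1 by ethyl in place of diethylamino on an aromatic carbon, with ethyl in place of diethylamino on an aromatic carbon. Among the compounds with values here, one measured step bears on this change: a 50-fold lower number from compound 1 to compound 3 (1.70 log units; beyond the scatter), which is large and beyond the scatter, with propyl in place of diethylamino. A similarly large fall in this assay is therefore expected, perhaps slightly smaller. The estimated step is a 17-fold lower number from compound 1 to compound 4 (1.22 log units; beyond the scatter). The expected value for compound 4 is 3 nM, with an estimated range of 0.7 nM to 15 nM.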

Compound 4, half-maximal inhibitory concentration: 1 nM
Estimate against measurement, compound 4: 3.0-fold (0.48 log units) above, and the stated range covers the measured number.
By their numbers in this assay, from the lowest: compounds 3 and 4 (each within the scatter of the next); then compound 1.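

In this assay, ethyl in place of diethylamino gives a 50-fold lower number from compound 1 to compound 4 (1.70 log units; beyond the scatter), so the large fall seen with propyl is not confined to that one chain. Hydrogen in place of methyl on the saturated chain gives no change at the digits printed from compound 3 to compound 4 (within the scatter), so this assay does not separate ethyl from propyl at this place. Nothing at hand accounts for the gap between these chains and diethylamino. As far as these compounds go, whether methyl or a longer chain such as butyl would give a similar number remains open. So does whether a smaller amine, such as dimethylamino, would stand with diethylamino or with the chains.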